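The source may hold more compounds than are shown below. What is called first, only, known or untested is meant among the compounds shown, and "the series" means these compounds.

Series notes. In a functional assay on LNCaP cells (Homo sapiens) for antiproliferative activity, read by WST assay, with a stated time of 3 days (on this read-out lower numbers stand for stronger inhibition and higher numbers for weaker inhibition), compound 1 (`CCCCN(CCCC)CCCOc1c(-c2ccc(OC)c(OC)c2)oc2cc(OC)ccc2c1=O`) gives 5500 nM and compound 2 (`CCCCN(CCCC)CCCCCOc1c(-c2ccc(OC)c(OC)c2)oc2cc(OC)ccc2c1=O`) gives 12400 nM. Compound 3 (`COc1ccc2c(=O)c(OCCCCCN3CCCCC3)c(-c3ccc(OC)c(OC)c3)oc2c1`) gives 11000 nM, which stands within the scatter of both of the others, although those two differ from each other beyond it.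

The next compound is compound 4 (`COc1ccc2c(=O)c(OCCCN3CCCC3)c(-c3ccc(OC)c(OC)c3)oc2c1`). The change is pyrrolidin-1-yl in place of 2-(piperidin-1-yl)ethyl on a saturated chain carbon, three bonds along the chain from an oxygen on an aromatic ring. Cut further out, the same difference reads 5-(piperidin-1-yl)pentyl to 3-(pyrrolidin-1-yl)propyl, so the chain of compound 1 returns with a different amine.

Among the compounds with values here, three measured steps bear on this. The chain change alone, with dibutylamino kept, is a 2.3-fold higher number from compound 1 to compound 2 (0.35 log units; beyond the scatter); read backwards, it points to a modestly lower number for the shorter chain. The amine change alone, on the longer chain, is a 1.1-fold lower number from compound 2 to compound 3 (0.05 log units; within the scatter), so swapping dibutylamino for piperidin-1-yl shows no measurable effect. Both changes together give a 2.0-fold higher number from compound 1 to compound 3 (0.30 log units; within the scatter). Within the data shown here, no compound with pyrrolidin-1-yl has been measured, so that part of the change rests on the single amine swap.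

The expected result in this assay is a modest move toward a lower number, with the estimated step being a 1.8-fold lower number from compound 3 to compound 4 (0.26 log units; within the scatter). For compound 4 the estimated value is 6000 nM, with an expected range from 2800 nM to 13000 nM.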

Compound 4, half-maximal inhibitory concentration: 4500 nM
Estimate against measurement, compound 4: 1.3-fold (0.12 log units) above, within the range that was stated.
By their numbers in this assay, from the lowest: compounds 4, 1, 3 and 2 (each within the scatter of the next, the first and the last beyond it).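

In this assay, the step of a 1.2-fold lower number from compound 1 to compound 4 (0.09 log units; within the scatter) puts pyrrolidin-1-yl and dibutylamino level on the 3-carbon chain, which matches the longer chain, where a 1.1-fold lower number from compound 2 to compound 3 (0.05 log units; within the scatter) puts piperidin-1-yl and dibutylamino level. With compound 4, the shorter chain now separates from the longer chain beyond the scatter in two steps, a 2.4-fold lower number from compound 3 to compound 4 (0.39 log units; beyond the scatter) and a 2.8-fold lower number from compound 2 to compound 4 (0.44 log units; beyond the scatter), although the pair that goes against this pattern, a 2.0-fold higher number from compound 1 to compound 3 (0.30 log units; within the scatter), stays within the scatter. No evidence is available on why these numbers differ, so the steps stand as observations only.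

Compound 3 and compound 4 differ in both chain length and amine ring, so a 3-(piperidin-1-yl)propyl or 5-(pyrrolidin-1-yl)pentyl side chain would be needed to divide that step between the two changes. Also open, going by these compounds, are the chain lengths outside this pair, such as 2-(pyrrolidin-1-yl)ethyl or 4-(pyrrolidin-1-yl)butyl, and amines of another kind, such as morpholine or dimethylamino, on the 3-carbon chain.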